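This account rests on a few compounds, and the source may have more. Where it says the series, first, only, none or still open, it means among the compounds named here.

In an ADME assay on microsomes from liver (Homo sapiens) for metabolic stability, read by LC-MS, using NADPH, with a stated time of 10 min, tested at 10 uM (a lower number here means that the compound disappears faster, a higher number that the compound lasts longer), compound 3 `N#Cc1ccnc(Oc2nn([C@H]3C[C@H](O)C3)c3ncnc(N)c23)c1` gives > 2.41 h, which is a limit and not a number. Compound 3 therefore stands at the limit of > 2.41 h in this assay, at which 2 of the 3 values shown sit. Compound 2 `Nc1ncnc2c1c(Oc1cc(C(F)(F)F)ccn1)nn2C1CC1`, which carries cyclopropyl on the aromatic nitrogen, gives > 2.41 h, also a limit. Compound 1 `N#Cc1ccnc(Oc2nn(C3CCC3)c3ncnc(N)c23)c1`, by contrast, gives a measured number of 2.35 h.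

Next comes compound 4 `N#Cc1ccnc(Oc2nn(C3CC3)c3ncnc(N)c23)c1`, with cyclopropyl in place of 3-hydroxycyclobutyl on an aromatic nitrogen. Going by the values given here, the one measured step bearing on this change is an at least 1.0-fold higher number from compound 1 to compound 3 (0.01 log units; that floor lies within the scatter). As far as these compounds go, that step is open on its upper side, so the true effect of the hydroxy remains unknown. Among the compounds with values here, no measured step isolates cyclopropyl against a four-membered ring. Within the data shown here, with only this evidence, no step beyond the scatter is expected in this assay, and the expected step is a number no higher from compound 3 to compound 4 (the limit leaves the size open). Compound 4 is estimated at 2.4 h, with an expected range of 1.5 h to 3.5 h.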

Compound 4, half-life: > 2.41 h
Compound 4: a limit, no number; the forecaster's own chance of this, stated with the estimate: 55%; middle value at least 1.0-fold (0.00 log units) from the limit.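

In this assay, going by these compounds alone, cyclopropyl in place of cyclobutyl on an aromatic nitrogen gives an at least 1.0-fold higher number from compound 1 to compound 4 (0.01 log units; that floor lies within the scatter), a first reading of a ring-size change at this position, though one that fixes only a floor and not the true size of the step. The steps to compound 4 from compound 3 and from compound 2 cannot be read: both ends of each are limits. Compound 4 joins compound 2 and compound 3 at one shared limit, so cyclopropyl with nitrile now sits there alongside 3-hydroxycyclobutyl with nitrile and cyclopropyl with trifluoromethyl: the limit of > 2.41 h in this assay, at which 3 of the 4 values shown sit.

As far as these compounds go, how far compound 2, compound 3 and compound 4 actually lie from that limit stays open, so no order among them can be given. Also open, from the compounds shown here alone, is how a longer alkyl chain, or a ring bearing an amine, would read in this assay in that same place.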